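From compound 3 to compound 4: a change on the amide

A few compounds are considered here, and "the series" means these few. Any claim that something is new, unique, unknown or untested is made for them only; others in the source may bear on it.

In an ADME assay on microsomes from liver (Rattus norvegicus) for metabolic stability (on this read-out lower numbers stand for a shorter-lived compound and higher numbers for a longer-lived compound), compound 3 (`Cc1nc(NC(=O)c2nc(C)n(-c3ccc(F)cc3)c2C)ccc1F`) gives 0.733 h and lies within the scatter of two measured compounds: compound 1 (`Cc1cccc(NC(=O)c2nn(C)c(-c3ccccc3)c2C)n1`), which gives 0.567 h here, and compound 2 (`Cc1nc(C(=O)Nc2cccc(F)n2)c(C)n1-c1ccc(F)cc1`), which gives 1.13 h here. Compound 4 (`Cc1nc(C(=O)Nc2ccnc(Cl)n2)c(C)n1-c1ccc(F)cc1`) differs on an amide-type nitrogen, where 2-chloropyrimidin-4-yl stands in place of 5-fluoro-6-methylpyridin-2-yl (2-chloropyrimidin-4-yl in place of 5-fluoro-6-methylpyridin-2-yl on an amide-type nitrogen). Within the data shown here, only one measured step bears on this place, a 1.5-fold lower number from compound 2 to compound 3 (0.19 log units; within the scatter) and it stayed within the scatter. Among the measured compounds shown here, no measured compound carries 2-chloropyrimidin-4-yl, so no step beyond the scatter is expected. The estimated step is a 1.1-fold higher number from compound 3 to compound 4 (0.04 log units; within the scatter) and no direction is favoured. The value expected for compound 4 is 0.8 h with an estimated range from 0.35 h to 1.8 h in this assay once it is measured.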

Compound 4, half-life: 2.75 h
Compound 4: the middle estimate sits 3.4-fold (0.54 log units) below what was measured; measured number above the stated range.
By their numbers in this assay, from the lowest: compounds 1, 3 and 2 (each within the scatter of the next); then compound 4.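

In this assay, the group on the amide-type nitrogen proves able to shift the half-life beyond the scatter: 2-chloropyrimidin-4-yl gives a 3.8-fold higher number from compound 3 to compound 4 (0.57 log units; beyond the scatter) and also a 2.4-fold higher number from compound 2 to compound 4 (0.39 log units; beyond the scatter). Among these compounds, the one earlier step at this place stayed within the scatter, so the position is more responsive than that step showed. Nothing at hand explains the rise.

The compounds shown do not separate the chlorine from the extra ring nitrogen as the source of the rise. From the compounds shown here alone, a methoxy group or an amine in place of the chlorine remains open.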